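Solubility notes: pyrazolyl for tolyl on the shared core

The source may report more compounds than this note shows. Statements on the series, on what has been measured and on what is new or still open speak of the compounds shown alone.

Measured so far:
compound 1 `Cc1ccc(-c2cnn3c(NCc4ccccn4)cc(C)nc23)cc1`, < 5000 nM
compound 2 `Cc1cc(NCc2ccncc2)n2nc(C)c(-c3ccccc3)c2n1`, 134000 nM
compound 3 `Cc1cc(NCc2ccc3ccccc3n2)n2nc(C)c(-c3ccccc3)c2n1`, < 5000 nM

In a physicochemical assay for solubility, read by HPLC, using the shake flask method, measured as kinetic solubility, with a stated time of 2 h, at pH 7.4 (a higher number here means a more soluble compound, a lower number a less soluble compound), compound 1 gives only a limit, < 5000 nM, not a number. Compound 3 also sits at a limit in this assay, < 5000 nM. Within the data shown here, compound 2 is the one compound with a number, 134000 nM. So compound 1 stands at the low end of what is shown, at the limit of < 5000 nM in this assay, at which 2 of the 3 values shown sit.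

Compound 4 `Cc1cc(NCc2ccccn2)n2ncc(-c3ccn(C)n3)c2n1` is not yet measured. It differs from compound 1 in one place: 1-methyl-1H-pyrazol-3-yl in place of 4-methylphenyl on an aromatic carbon.

Among the measured compounds shown here, no step between measured compounds is available, so the size of the step from compound 1 to compound 4 in this assay is an expectation only. An upward step beyond the scatter is expected, an at least 6.0-fold higher number from compound 1 to compound 4 (0.77 log units; beyond the scatter). For compound 4 a solubility of 30000 nM is estimated, within 5000 nM to 150000 nM.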

Compound 4, solubility: 188000 nM
Estimate against measurement, compound 4: 6.3-fold (0.80 log units) below; the whole stated range lies below it.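

In this assay, 1-methyl-1H-pyrazol-3-yl in place of 4-methylphenyl on an aromatic carbon gives an at least 37-fold higher number from compound 1 to compound 4 (1.57 log units; beyond the scatter), the only single-place step shown in the series, and it falls at this position. On these data alone, compound 1 gives < 5000 nM, which is a limit, so the full size of the step stays unknown: the limit of < 5000 nM in this assay, at which 2 of the 4 values shown sit. The change replaces a six-membered aromatic ring of carbon only, with 0 hydrogen-bond acceptors, by a five-membered aromatic ring with 2 hetero atoms and 2 hydrogen-bond acceptors.

This single step cannot separate those features. As far as these compounds go, whether a pyridine ring, an amine or a carboxylic acid on this carbon would give a step of similar size remains open.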